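Notes on compound 4, the methoxy analogue of compound 2

This account rests on a few compounds, and the source may have more. Where it says the series, first, only, none or still open, it means among the compounds named here.

Measured in a functional assay on A549 cells (Homo sapiens), read by MTT assay, with a stated time of 72 h; on this read-out higher numbers stand for weaker inhibition and lower numbers for stronger inhibition:
compound 1 `Nc1nc2c(c(-c3ccccc3)cn2[C@@H]2O[C@H](CO)[C@@H](O)[C@H]2O)c(=O)[nH]1`: > 100000 nM, a limit only.
compound 2 `CN(C)c1ncnc2c1c(-c1cc3ccccc3o1)cn2[C@@H]1O[C@H](CO)[C@@H](O)[C@H]1O`: > 20000 nM, a limit only.
compound 3 `C#Cc1cn([C@@H]2O[C@H](CO)[C@@H](O)[C@H]2O)c2ncnc(N(C)C)c12`: 390 nM.

Compound 2 stands at a limit, (the limit of > 20000 nM in this assay, at which 1 of the 3 values shown sits), so no number is known for it; compound 1 sits at the other limit, (the limit of > 100000 nM in this assay, at which 1 of the 3 values shown sits). Compound 4 `COc1ncnc2c1c(-c1cc3ccccc3o1)cn2[C@@H]1O[C@H](CO)[C@@H](O)[C@H]1O` differs from compound 2 by methoxy in place of dimethylamino on an aromatic carbon. Going by the values given here, the only measured step, an at least 51-fold lower number from compound 2 to compound 3 (1.70 log units; beyond the scatter), concerns a different group on another carbon of the shared core and does not bear on this change; no measured step does. Compound 4 is therefore expected to stay weak, at 30000 nM with a range of 6000 nM to 100000 nM, an expected step that the limit leaves unreadable from compound 2 to compound 4, with a real chance that this assay again reports only a limit.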

Compound 4, half-maximal inhibitory concentration: 17700 nM
Compound 4: the middle estimate sits 1.7-fold (0.23 log units) above what was measured; the measured number falls inside the stated range.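

In this assay compound 4 gives a real number at this position, which the earlier benzofuran compound did not. The value of compound 2 is a limit only: the limit of > 20000 nM in this assay, at which 1 of the 4 values shown sits.

Methoxy in place of dimethylamino on this aromatic carbon gives an at least 1.1-fold lower number from compound 2 to compound 4 (0.05 log units; that floor lies within the scatter), so no change in potency can be claimed from the swap, and the pair still reads as weak.

Going by these compounds, it remains open whether a primary amine or a longer alkoxy chain on this carbon would read differently. On these data alone, it is also open whether methoxy would behave the same way with the ethynyl group of compound 3 on the shared core.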